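This account rests on a few compounds, and the source may have more. Where it says the series, first, only, none or still open, it means among the compounds named here.

Measured compounds and their values:
compound 1 `Cc1c(Cc2c(Cl)cccc2Cl)nc(SCC(=O)c2ccc(F)cc2)[nH]c1=O`: > 57000 nM
compound 2 `COc1ccc(C(=O)CSc2nc(Cc3c(Cl)cccc3Cl)c(C)c(=O)[nH]2)cc1`: > 56000 nM
compound 3 `O=C(CSc1nc(Cc2c(F)cccc2Cl)cc(=O)[nH]1)c1ccc(F)cc1`: > 61000 nM

All three values come from an ADME assay on MT4 cells (Homo sapiens) for cytotoxicity, read by MTT assay; on this read-out higher numbers stand for lower toxicity in this test and lower numbers for higher toxicity in this test. For compound 1 the figure > 57000 nM is a limit of this assay, not a number. For compound 2 the figure > 56000 nM is likewise a limit. For compound 3 the figure > 61000 nM is a limit as well.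

Compound 1 and compound 2 differ in one place, (methoxy in place of fluoro on an aromatic carbon). Within the data shown here, since both values sit at limits, the step that the two limits leave unreadable from compound 1 to compound 2 cannot be read; what is known is only that neither compound reached the toxic range of this assay, which is what the limit of > 57000 nM in this assay, at which 1 of the 3 values shown sits, and the limit of > 56000 nM in this assay, at which 1 of the 3 values shown sits, record.

Compound 3 carries a different core from compound 1; the difference between the two cores is not broken down here. Compound 4 `COc1ccc(C(=O)CSc2nc(Cc3c(F)cccc3Cl)cc(=O)[nH]2)cc1` has not yet been measured in this assay. Among the measured compounds shown here, it differs from compound 3 by methoxy in place of fluoro on an aromatic carbon, the same change as the one from compound 1 to compound 2.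

Compound 4 is therefore expected to show the step that the limit leaves unreadable from compound 3 to compound 4, an expectation resting on the fact that compound 3 gave only a limit, (the limit of > 61000 nM in this assay, at which 1 of the 3 values shown sits), and that the earlier change did not bring compound 2 into measurable toxicity. Compound 4 is estimated to give 80000 nM in this assay, with the range 50000 nM to 200000 nM, and most likely only a limit will be reported.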

Compound 4, half-maximal cytotoxic concentration: > 12000 nM
Compound 4 was reported as a limit (the forecaster's own chance of this, stated with the estimate: 85%); the middle value lies beyond the limit too.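

In this assay compound 4 gives > 12000 nM, which is a limit and not a number. Compound 3 gives > 61000 nM, also a limit. The step between compound 3 and compound 4, 4-fluorophenyl to 4-methoxyphenyl, therefore cannot be read. The compounds shown leave open at what concentration any of them would turn toxic in this assay, and whether this change moves that concentration at all.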